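The source may hold more compounds than are shown below. What is called first, only, known or untested is meant among the compounds shown, and "the series" means these compounds.

For the measured compounds named here, compound 1 `O=C1N/C(=N/c2csc(-c3ccc(Cl)cc3)c2)S/C1=C\c1ccc(Br)cc1` is the only member of this series with a result on record: in a functional assay on SW-620 cells (Homo sapiens) for cytotoxicity, read by MTT assay, with a stated time of 72 h (on this read-out lower numbers stand for stronger inhibition and higher numbers for weaker inhibition), compound 1 gives 700 nM. Compound 2 `O=C1N/C(=N/c2csc(-c3ccc(Cl)cc3)c2)S/C1=C\c1ccc(O)cc1` shares the core but carries a different group on the exocyclic double bond, and for compound 2 this assay reports "not determined" (no result reported). Compound 3 `CCCCCC/C=C1\S/C(=N\c2csc(-c3ccc(Cl)cc3)c2)NC1=O` stands without a number as well, its entry in this assay being "not determined" (no result reported), so compound 3 cannot be placed against compound 1 and is one of two compounds in the set without a single figure.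

Compound 4 `O=C1N/C(=N/c2csc(-c3ccc(Cl)cc3)c2)S/C1=C\c1ccccn1` arises from compound 3 through one change: pyridin-2-yl in place of hexyl on a double-bonded chain carbon bound to a double-bonded ring carbon. Going by the values given here, with no measured step between any two compounds of the set, the direction and size of this change are not anchored in data; the only numerical point of reference is compound 1 with its chlorophenyl-thienyl core intact. On that basis compound 4 is expected to fall in the same general region as compound 1, with wide uncertainty, giving an estimate of 1500 nM in this assay, within 300 nM to 8000 nM.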

Compound 4, half-maximal inhibitory concentration: > 50000 nM
Compound 4 was reported as a limit; the forecaster's own chance of this, stated with the estimate: 25%; middle value at least 33-fold (1.52 log units) from the limit.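

For compound 4 the entry in this assay is a limit and not a number: the limit of > 50000 nM in this assay, at which 1 of the 4 values shown sits. Putting pyridin-2-yl in place of 4-bromophenyl on a double-bonded chain carbon bound to a double-bonded ring carbon gives an at least 71-fold higher number from compound 1 to compound 4 (1.85 log units; beyond the scatter). The earlier compounds shown here offered one figure and no step, and only now is it seen that the group at this place can decide the read-out on the shared core, and that a six-membered aromatic ring there is not enough by itself to hold the level of compound 1.

Steps involving compound 2 or compound 3 cannot be read, as neither has a number. The compounds shown leave open whether the ring nitrogen or the lost bromine counts here, which a plain phenyl or a 4-chlorophenyl at this place would help to separate.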